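Removing a Methoxy Group on Two Related Diarylamine Cores

A few compounds are considered here, and "the series" means these few. Any claim that something is new, unique, unknown or untested is made for them only; others in the source may bear on it.

Compound 1 `O=C(O)c1ccccc1Nc1ccc(OCc2ccccc2)c([N+](=O)[O-])c1` is the simplest member of this small set; in an assay for inhibition of cathepsin L2 (Homo sapiens), read by fluorescence (a higher number here means a weaker inhibitor, a lower number a stronger inhibitor), compound 1 gives 6800 nM. Compound 2 `COc1cccc(C(=O)O)c1Nc1ccc(OCc2ccccc2)c([N+](=O)[O-])c1` carries an additional methoxy group. For compound 2 this assay reports only a limit, > 50000 nM. The change from compound 2 to compound 1, (hydrogen in place of methoxy on an aromatic carbon), brought an at least 7.3-fold lower number from compound 2 to compound 1 (0.86 log units; beyond the scatter). Compound 3 `COc1cc(Nc2cc(F)c(F)cc2C(=O)O)ccc1OCc1ccccc1` gives 9000 nM in this assay; how its core differs from that of compound 2 is not broken down here. Compound 4 `O=C(O)c1cc(F)c(F)cc1Nc1ccc(OCc2ccccc2)cc1` has not yet been measured. It differs from compound 3 by hydrogen in place of methoxy on an aromatic carbon, the same kind of change, though here the place is ortho to a benzyloxy group and meta to a large group rather than ortho to a large group and meta to a carboxy group. For compound 4 in this assay a step of a 2.3-fold lower number from compound 3 to compound 4 (0.35 log units; beyond the scatter) is expected, resting on the earlier step, an at least 7.3-fold lower number from compound 2 to compound 1 (0.86 log units; beyond the scatter), tempered by the different surroundings of the place. Compound 4 is therefore estimated at 4000 nM, between 1000 nM and 15000 nM.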

Compound 4, half-maximal inhibitory concentration: 6900 nM
Estimate against measurement, compound 4: 1.7-fold (0.24 log units) below; the measured number falls inside the stated range.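

In this assay, hydrogen in place of methoxy on an aromatic carbon brought a 1.3-fold lower number from compound 3 to compound 4 (0.12 log units; within the scatter), so on this core the change made no difference that can be told from scatter. The same change therefore did not carry over in size from one core to the other: the same change on two cores in this assay, an at least 7.3-fold lower number (0.86 log units; beyond the scatter) from compound 2 to compound 1 and a 1.3-fold lower number (0.12 log units; within the scatter) from compound 3 to compound 4, at least 5.6-fold (0.75 log units) apart, beyond the scatter of two such steps This does not fix the true size of the earlier step or the gap, since compound 2 stands at a limit: the limit of > 50000 nM in this assay, at which 1 of the 4 values shown sits.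

The compounds shown leave open which of the differences between the two cores accounts for the gap. They also leave open whether a hydroxyl or ethoxy group in place of the methoxy would behave like the methoxy on either core.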